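What Removing One Methyl Group May Do

The source may hold more compounds than are shown below. What is called first, only, known or untested is meant among the compounds shown, and "the series" means these compounds.

Two closely related compounds have been measured so far. In a functional assay on HeLa cells (Homo sapiens) for antiproliferative activity, read by sulforhodamine B assay, with a stated time of 48 h (on this read-out higher numbers stand for weaker inhibition and lower numbers for stronger inhibition), compound 1 `COc1cc(OC)c2sc(-c3ccc(N/C=C\C(=O)c4cc(OC)c(OC)c([N+](=O)[O-])c4)c(C)c3)nc2c1` gives 11400 nM and compound 2 `COc1cc(OC)c2sc(-c3ccc(N/C=C\C(=O)c4cc(OC)c(OC)c(OC)c4)c(C)c3)nc2c1` gives 16400 nM. Going by the values given here, compound 1 therefore stands level with its only measured neighbour, since the two numbers lie within the scatter of repeated measurements.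

The next compound, compound 3 `COc1cc(OC)c2sc(-c3ccc(N/C=C\C(=O)c4cc(OC)c(OC)c([N+](=O)[O-])c4)cc3)nc2c1`, differs from compound 1 in a single place: hydrogen in place of methyl on an aromatic carbon. Put simply, this is hydrogen in place of methyl on an aromatic carbon.

Among the compounds with values here, the only measured step is a 1.4-fold higher number from compound 1 to compound 2 (0.16 log units; within the scatter). It swaps nitro for methoxy, so it bears on this change only indirectly, as a sign that one small swap on this scaffold left the number within the scatter. Within the data shown here, no measured pair shows what losing the methyl does. No step beyond the scatter is therefore expected in this assay, and no direction can be favoured with confidence.

The expected step is a 1.1-fold higher number from compound 1 to compound 3 (0.02 log units; within the scatter). For compound 3 the estimated value is 12000 nM, with an expected range from 4000 nM to 36000 nM.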

Compound 3, half-maximal inhibitory concentration: 19000 nM
The estimate for compound 3 lay 1.6-fold (0.20 log units) below the measured number, and the stated range covers the measured number.
By their numbers in this assay, from the lowest: compounds 1, 2 and 3 (each within the scatter of the next).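

In this assay, going by these compounds alone, hydrogen in place of methyl on this aromatic carbon gives a 1.7-fold higher number from compound 1 to compound 3 (0.22 log units; within the scatter) and so provides the first direct reading at this position, where the earlier step could speak to it only indirectly. In this pair, which carries nitro on the other aromatic ring, the single carbon of the methyl group can go without a step beyond the scatter, so the methyl is not needed to hold the number at this level, though that conclusion rests on one pair alone. No supporting measurement is available to explain this result.

The compounds shown leave open whether hydrogen in place of methyl would read the same way in compound 2, which carries methoxy where compound 1 carries nitro. They also leave open what other groups on this aromatic carbon, such as an ethyl chain, a chlorine atom or an amine, would do to the number, and whether any of them would produce a step beyond the scatter.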